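Chloro-to-hydrogen step in a cytotoxicity series

This account rests on a few compounds, and the source may have more. Where it says the series, first, only, none or still open, it means among the compounds named here.

Measured in a functional assay on L1210 cells (Mus musculus) for cytotoxicity, with a stated time of 48 h; a lower number here means a stronger inhibitor, a higher number a weaker inhibitor:
compound 1, `O=C1/C(=C/c2ccc(Cl)cc2)CCC/C1=C\c1ccc([N+](=O)[O-])cc1`: 9410 nM
compound 2, `O=C1/C(=C/c2ccc(Cl)cc2)CCC/C1=C\c1ccccc1[N+](=O)[O-]`: 9380 nM
compound 3, `O=C1/C(=C/c2ccccc2)CCC/C1=C\c1ccc([N+](=O)[O-])cc1`: 9800 nM

Compound 1 and compound 2 are built from the same atoms joined differently; the difference between the two cores is not broken down here. Their values in this assay lie within the scatter of each other, as does the value of compound 3.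

From compound 1 to compound 3 the change is hydrogen in place of chloro on an aromatic carbon and the step is a 1.0-fold higher number from compound 1 to compound 3 (0.02 log units; within the scatter).

Compound 4, `O=C1/C(=C/c2ccccc2)CCC/C1=C\c1ccccc1[N+](=O)[O-]`, is not yet measured in this assay. From compound 2 to compound 4 the change is hydrogen in place of chloro on an aromatic carbon, the same change as from compound 1 to compound 3, at a place described in the same words. On that ground the step from compound 2 to compound 4 is expected to be a 1.0-fold higher number from compound 2 to compound 4 (0.01 log units; within the scatter), resting on compound 1 and compound 3, whose step is a 1.0-fold higher number from compound 1 to compound 3 (0.02 log units; within the scatter). Compound 4 is therefore estimated at 9500 nM, expected between 5000 nM and 18000 nM.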

Compound 4, half-maximal inhibitory concentration: 4840 nM
Compound 4: middle estimate off by 2.0-fold (0.29 log units), on the high side; measured number below the stated range.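

In this assay, the chloro-to-hydrogen change on the core of compound 2 gives a 1.9-fold lower number from compound 2 to compound 4 (0.29 log units; within the scatter), so this step, like the earlier one, cannot be told from the scatter. Set side by side, the two steps do not separate from each other: the same change on two cores in this assay, a 1.0-fold higher number (0.02 log units; within the scatter) from compound 1 to compound 3 and a 1.9-fold lower number (0.29 log units; within the scatter) from compound 2 to compound 4, 2.0-fold (0.30 log units) apart, within the scatter of two such steps. Within these two pairs, the 4-chlorophenyl to phenyl change therefore carries from one core to the other without a detectable difference, but with one pair per core this does not show that the two cores respond identically, nor does it say how the change would read on any further core.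

Open is how an amine or a methoxy group would read at the place of the chloro, since the compounds shown carry only chloro or hydrogen there. Also open, as far as these compounds go, is whether the same reading would hold if a carboxylic acid or a nitrile took the place of the nitro group.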